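Bromo for methyl on the aryl ring of the shared core

The compounds below may be only part of what the source reports. "The series", "measured", "known", "first", "only" and "open" are said of these compounds alone.

Three compounds of the shared core have a measurement in a functional assay on HeLa cells (Homo sapiens) for inhibition; a higher number here means a weaker inhibitor, a lower number a stronger inhibitor. Compound 1 `CC(C)NC1CC(=O)N(c2ccc(F)c(Cl)c2)C1OCC(F)(F)F` gives 6610 nM; compound 2 `Cc1ccc(N2C(=O)C=CC2OCC(F)(F)F)cc1` gives 9380 nM; compound 3 `O=C1C=CC(OCC(F)(F)F)N1c1ccc(Cl)cc1F` gives 8320 nM. Compound 2 holds the highest of the three numbers, but its gaps to compound 3 and to compound 1 both lie within the usual scatter, so the three read as one level.

Compound 4 `O=C1C=CC(OCC(F)(F)F)N1c1ccc(Br)cc1` has not been measured. It differs from compound 2 by bromo in place of methyl on an aromatic carbon. Among the measured compounds shown here, no measured pair shows this change. Compound 1, which carries halogen on its aryl ring, gives 6610 nM and compound 3 gives 8320 nM, both within the scatter of compound 2, so no step beyond the scatter is expected. For compound 4 the estimated value in this assay is 9000 nM, with a range from 4000 nM to 20000 nM. The step expected from compound 2 to compound 4 is a 1.0-fold lower number from compound 2 to compound 4 (0.02 log units; within the scatter).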

Compound 4, half-maximal inhibitory concentration: 7060 nM
The estimate for compound 4 lay 1.3-fold (0.11 log units) above the measured number; the range from low to high includes it.
By their numbers in this assay, from the lowest: compounds 1, 4, 3 and 2 (each within the scatter of the next).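

Bromo in place of methyl on an aromatic carbon, para to a large group, is the only single-place change available in this assay, and it gives a 1.3-fold lower number from compound 2 to compound 4 (0.12 log units; within the scatter) with no separation of the two groups at this position. At this level of inhibition, the position therefore tolerates the exchange of methyl for bromo. Nothing at hand bears on the reason for this result.

Going by these compounds, whether an amine or a carboxylic acid on this carbon would move the number beyond the scatter remains open. On these data alone, the effect of single-place changes elsewhere on the shared core also remains open.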